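The source may hold more compounds than are shown below. What is called first, only, known or untested is meant among the compounds shown, and "the series" means these compounds.

Series notes. Compound 1 `CC(=O)Nc1ccc(O)c(C(=O)OCCn2c([N+](=O)[O-])cnc2C)c1` in a functional assay on the whole organism (strain Wistar) for inhibition, with Rattus norvegicus as the target, read by paw edema, with stated times of 1 h and 3 h, at a dose of 10 mg/kg by the intraperitoneal route (a lower number here means less inhibition, a higher number more inhibition at the dose given (going by the name of the read-out)), gives 16.6%. Compound 2 `Cc1ncc([N+](=O)[O-])n1CCOC(=O)c1cc(NC(=O)[C@H](C)NC(=O)OCc2ccccc2)ccc1O` in this assay gives 37.1%, the higher of the two values recorded, and its gap to compound 1 is beyond the scatter. Compound 3 `Cc1ncc([N+](=O)[O-])n1CCOC(=O)c1cc(NC(=O)CNC(=O)OCc2ccccc2)ccc1O` is not yet measured; it differs from compound 2 by hydrogen in place of methyl on a saturated chain carbon bound to an amide-type nitrogen and a carbonyl carbon. Within the data shown here, no measured pair shows a change of this kind, so the step from compound 2 to compound 3 is expected to be small in this assay, with no direction beyond the scatter, an expected step of a number 4.1 percentage points lower from compound 2 to compound 3 (within the scatter). Compound 3 is thus estimated at 33%, within 18% to 48%.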

Compound 3, a percentage reported as inhibition, in the whole organism at one dose (the size of the read-out at that dose, not a potency): 57%
The estimate for compound 3 lay 24 percentage points below the measured number; measured number above the stated range.
By their numbers in this assay, from the lowest: compound 1; then compound 2; then compound 3.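

In this assay, hydrogen in place of methyl on the saturated chain carbon bound to an amide-type nitrogen and a carbonyl carbon gives a number 19.9 percentage points higher from compound 2 to compound 3 (beyond the scatter) and shows that this position responds to a change of a single carbon. With hydrogen at that carbon, (benzyloxycarbonyl)amino in place of hydrogen on the chain carbon gives a number 40.4 percentage points higher from compound 1 to compound 3 (beyond the scatter) and ties the higher read-out to that group in this pair. Nothing at hand accounts for either step.

Going by these compounds, whether an ethyl group in place of the methyl lowers the read-out further remains open. So does whether a free amine in place of the (benzyloxycarbonyl)amino group holds it.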